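A few compounds are considered here, and "the series" means these few. Any claim that something is new, unique, unknown or untested is made for them only; others in the source may bear on it.

Going by the values given here, in a functional assay on HeLa cells (Homo sapiens) for antiproliferative activity, read by WST assay, with a stated time of 72 h (a higher number here means a weaker inhibitor, a lower number a stronger inhibitor), compound 1 `COC(=O)/C=C/c1ccc(NCc2ccccc2O)cc1` gives 7170 nM, the higher of the two numbers so far. Compound 2 `COC(=O)/C=C/c1ccc(NCc2cccc(OC)c2O)cc1` gives 3040 nM. Compound 3 `COC(=O)/C=C/c1ccc(NCc2cc([N+](=O)[O-])ccc2O)cc1` carries nitro in place of hydrogen on an aromatic carbon, that is, nitro in place of hydrogen on an aromatic carbon, para to a hydroxy group. Among the compounds with values here, the only measured step, a 2.4-fold lower number from compound 1 to compound 2 (0.37 log units; beyond the scatter), is modest and beyond the scatter, but it involves methoxy rather than nitro, so it is a weak guide. A similarly modest move to a lower number is expected in this assay, and the expected step is a 1.8-fold lower number from compound 1 to compound 3 (0.25 log units; within the scatter). For compound 3 the estimated value is 4000 nM, with an expected range of 1500 nM to 10000 nM.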

Compound 3, half-maximal inhibitory concentration: 16000 nM
Beside the measured number, compound 3's estimate is 4.0-fold (0.60 log units) below it, outside the stated range (above it).
By their numbers in this assay, from the lowest: compound 2; then compound 1; then compound 3.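

In this assay nitro on an aromatic carbon, para to a hydroxy group, gives a 2.2-fold higher number from compound 1 to compound 3 (0.35 log units; beyond the scatter) and so moves the number upward. The earlier step, a 2.4-fold lower number from compound 1 to compound 2 (0.37 log units; beyond the scatter), went downward, so substitution on this ring does not move the number in one direction only, although that step has a different group at a different place. Nothing at hand accounts for the rise.

The compounds shown leave open whether the rise belongs to nitro itself or to this position. An amine or a methoxy at the same place, para to a hydroxy group, would help separate the two.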